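The source may hold more compounds than are shown below. What is called first, only, known or untested is meant among the compounds shown, and "the series" means these compounds.

Two compounds share a common core and differ only in the aryl group on the double-bonded chain carbon. Compound 1 `CN(C)c1ccc(C=C2C(=O)N(c3ccc(Cl)cc3)N(c3ccc(Cl)cc3)C2=O)cc1` carries a 4-(dimethylamino)phenyl there, and in a functional assay on MGC-803 cells (Homo sapiens) for cytotoxicity, read by MTT assay, with a stated time of 72 h (on this read-out higher numbers stand for weaker inhibition and lower numbers for stronger inhibition), compound 1 gives 80200 nM. Compound 2 `COc1cc(C=C2C(=O)N(c3ccc(Cl)cc3)N(c3ccc(Cl)cc3)C2=O)ccc1O` carries a 4-hydroxy-3-methoxyphenyl instead, and in this assay compound 2 gives 21800 nM, the lowest of the two numbers, with a 3.7-fold lower number from compound 1 to compound 2 (0.57 log units; beyond the scatter).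

Compound 3 `COc1ccc(C=C2C(=O)N(c3ccc(Cl)cc3)N(c3ccc(Cl)cc3)C2=O)cc1OC` differs from compound 2 by methyl in place of hydrogen on an oxygen on an aromatic ring, so hydroxy becomes methoxy and 4-hydroxy-3-methoxyphenyl becomes 3,4-dimethoxyphenyl. Going by the values given here, the one measured step exchanged an entire aryl group and therefore says nothing about capping this single oxygen with a methyl; no measured step bears on the change. With nothing pointing in either direction, the expectation is a step of a 1.1-fold higher number from compound 2 to compound 3 (0.06 log units; within the scatter), within the scatter. Compound 3 is therefore estimated at 25000 nM in this assay, between 9000 nM and 70000 nM.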

Compound 3, half-maximal inhibitory concentration: > 128000 nM
Compound 3: only a limit was reported (the forecaster's own chance of this, stated with the estimate: 10%); at least 5.1-fold (0.70 log units) between middle value and limit.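

Capping this one oxygen matters: methyl in place of hydrogen, which turns hydroxy into methoxy, gives an at least 5.8-fold higher number from compound 2 to compound 3 (0.76 log units; beyond the scatter) in this assay, so the measured change at this single position is larger than the earlier whole-aryl exchange suggested nothing about. Compound 3 yields only a limit of the read-out, not a number: the limit of > 128000 nM in this assay, at which 1 of the 3 values shown sits. Putting 3,4-dimethoxyphenyl in place of 4-(dimethylamino)phenyl gives an at least 1.5-fold higher number from compound 1 to compound 3 (0.20 log units; that floor lies within the scatter), so that pair has no settled order.

Going by these compounds, how far beyond its limit compound 3 really lies remains unknown. Also open, on these data alone, is whether any cap on this oxygen acts like methyl, and what an ethoxy group, an acetate ester or an amine there would do, or a plain 4-hydroxyphenyl group without the methoxy.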